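From a methyl oxopiperidine to an acetyl morpholine

A few compounds are considered here, and "the series" means these few. Any claim that something is new, unique, unknown or untested is made for them only; others in the source may bear on it.

Of the compounds shown here, two sharing one core have so far been read in a physicochemical assay for solubility, read by spectrophotometry, measured as kinetic solubility, at pH 8, tested at 500 uM; a lower number here means a less soluble compound, a higher number a more soluble compound. There, compound 1 `CC(=O)N1CCC(NC(=O)c2ccncc2Nc2cc(-c3ccc4ccn(C)c4c3)c3nccnc3c2)CC1` gives 213 ug/mL, while compound 2 `CN1CCC(NC(=O)c2ccncc2Nc2cc(-c3ccc4ccn(C)c4c3)c3nccnc3c2)CC1=O` gives 48 ug/mL, the lower of the two numbers.

Compound 3 `CC(=O)N1CCOC(CNC(=O)c2ccncc2Nc2cc(-c3ccc4ccn(C)c4c3)c3nccnc3c2)C1` keeps the core and changes the group again, with (4-acetylmorpholin-2-yl)methyl in place of 1-methyl-2-oxopiperidin-4-yl on an amide-type nitrogen.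

Going by the values given here, only one measured step bears on this change. It is a 4.4-fold lower number from compound 1 to compound 2 (0.65 log units; beyond the scatter), a modest step beyond the scatter, and it replaced 1-acetylpiperidin-4-yl, a group that carries an acetyl. Compound 3 carries an acetyl once more, so part of that step may plausibly be regained. Among the compounds with values here, the guide is rough, since no measured compound holds a morpholine ring and two numbers show no firm pattern. The expected change in this assay is therefore upward, of similar or somewhat smaller size, and the estimate is a 2.7-fold higher number from compound 2 to compound 3 (0.43 log units; beyond the scatter). For compound 3 the estimated value is 130 ug/mL, with an expected range from 55 ug/mL to 260 ug/mL.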

Compound 3, solubility: 268 ug/mL
Beside the measured number, compound 3's estimate is 2.1-fold (0.31 log units) below it; measured number outside the range, above it.
By their numbers in this assay, from the lowest: compound 2; then compounds 1 and 3 (each within the scatter of the next).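

In this assay, the change from the methyl oxopiperidine to the acetyl morpholine gives a 5.6-fold higher number from compound 2 to compound 3 (0.75 log units; beyond the scatter), so this group on the amide-type nitrogen has now moved the number clearly in both directions on the shared core. The comparison with the other acetyl-bearing compound gives a 1.3-fold higher number from compound 1 to compound 3 (0.10 log units; within the scatter), which means that replacing 1-acetylpiperidin-4-yl with (4-acetylmorpholin-2-yl)methyl, a swap that alters the ring and adds a methyl link to the amide-type nitrogen, leaves no readable difference; among these three, the two compounds with an acetyl stand together and compound 2, without one, stands apart, though this is only a co-occurrence in a very small set. No measurement shown here explains why the number moves with these groups.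

Because the ring, the acetyl and the methyl link all differ at once between compound 2 and compound 3, the contribution of each stays unresolved. As far as these compounds go, a morpholine without the acetyl, a 1-acetylpiperidine joined through the same methyl link, or a ring bearing a free amine would each separate these features, and their effect on this read-out remains open.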